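This account rests on a few compounds, and the source may have more. Where it says the series, first, only, none or still open, it means among the compounds named here.

Measured compounds:

Compound 1, `O=C(/C=C\c1ccc(O)cc1)N1N=C(c2ccncc2)OC1c1c[nH]c2ccccc12`: in an ADME assay on HeLa cells (Homo sapiens) for cytotoxicity, read by MTT assay, with a stated time of 72 h (a lower number here means a stronger inhibitor of growth, a higher number a weaker inhibitor of growth), compound 1 gives > 30 ug/mL, which is a limit of the assay and not a number.
Compound 2, `Cc1ccc(/C=C\C(=O)N2N=C(c3ccncc3)OC2c2c[nH]c3ccccc23)cc1`: compound 2 gives > 30 ug/mL, again only a limit.
Compound 3, `COc1ccc(/C=C\C(=O)N2N=C(c3ccncc3)OC2c2c[nH]c3ccccc23)cc1`: compound 3 gives > 30 ug/mL, also a limit.

Compound 3 therefore stands at the limit of > 30 ug/mL in this assay, at which 3 of the 3 values shown sit, with no number of its own. The three steps among the measured compounds are a step that the two limits leave unreadable from compound 1 to compound 2, a step that the two limits leave unreadable from compound 1 to compound 3 and a step that the two limits leave unreadable from compound 2 to compound 3; none of them can be read, because every value involved sits at the limit of > 30 ug/mL in this assay, at which 3 of the 3 values shown sit.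

The step to be followed is 2,4-dichlorophenyl in place of 4-methoxyphenyl on a double-bonded chain carbon bound to a double-bonded chain carbon, giving compound 4, `O=C(/C=C\c1ccc(Cl)cc1Cl)N1N=C(c2ccncc2)OC1c1c[nH]c2ccccc12`. Among the measured compounds shown here, this exchange has no measured counterpart: the readable steps so far concern only hydroxy, methyl and methoxy, and all were unreadable in this assay. No direction and no size beyond the scatter can be taken from them.

The expectation is that compound 4 behaves like the three measured compounds and most likely returns only a limit in this assay. Compound 4 is estimated at 40 ug/mL, with a range from 12 ug/mL to 150 ug/mL. For the measured compounds named here, the expected step that the limit leaves unreadable from compound 3 to compound 4 is an estimate only, with no measured step behind it.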

Compound 4, concentration for 50% growth inhibition: 29.3 ug/mL
Compound 4: the middle estimate sits 1.4-fold (0.14 log units) above what was measured; measured number inside the range.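

In this assay, 2,4-dichlorophenyl in place of 4-methoxyphenyl on a double-bonded chain carbon bound to a double-bonded chain carbon gives the only number among the four compounds shown, and the change reads as an at least 1.0-fold lower number from compound 3 to compound 4 (0.01 log units; that floor lies within the scatter), alongside an at least 1.0-fold lower number from compound 2 to compound 4 (0.01 log units; that floor lies within the scatter) and an at least 1.0-fold lower number from compound 1 to compound 4 (0.01 log units; that floor lies within the scatter). Each of these is only a floor that lies within the scatter, so this position is shown to tolerate the exchange without any real gain being established, while a larger true step is not excluded. The steps among compound 1, compound 2 and compound 3 still cannot be read, and the new steps remain floors, because those three compounds carry only a limit: the limit of > 30 ug/mL in this assay, at which 3 of the 4 values shown sit.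

From the compounds shown here alone, it remains open whether both chlorine atoms are needed for compound 4 to give a number, or whether a phenyl ring carrying one chlorine, an amine or a carboxylic acid would do the same. Also open, going by these compounds, is how a longer chain in place of the ethenyl link in 2-(2,4-dichlorophenyl)ethenyl would read in this assay.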